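The source may report more compounds than this note shows. Statements on the series, on what has been measured and on what is new or still open speak of the compounds shown alone.

Measured in a functional assay on the whole organism with Rattus norvegicus as the target; a lower number here means that less compound is needed, a higher number that more compound is needed for the effect:
- Compound 1 `C=C/C=C/[C@](C)(O)C/C=C/[C@H]1[C@H](O)CC(=O)[C@@H]1CC/C=C\CCC(=O)OC`: 0.243 mg/kg
- Compound 2 `C/C=C(C)/C=C/[C@](C)(O)C/C=C/[C@H]1[C@H](O)CC(=O)[C@@H]1CC/C=C\CCC(=O)OC`: 0.185 mg/kg
- Compound 3 `C=C(C)/C=C/[C@](C)(O)C/C=C/[C@H]1[C@H](O)CC(=O)[C@@H]1CC/C=C\CCC(=O)OC`: 0.42 mg/kg

In this assay, compound 3 stands closest to compound 1, with a 1.7-fold higher number from compound 1 to compound 3 (0.24 log units; within the scatter). Compound 2 lies further off, with a 2.3-fold higher number from compound 2 to compound 3 (0.36 log units; beyond the scatter).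

Compound 4 `C=C/C=C(\C)[C@](C)(O)C/C=C/[C@H]1[C@H](O)CC(=O)[C@@H]1CC/C=C\CCC(=O)OC` has the same atoms as compound 3, joined differently: 1-methylbuta-1,3-dien-1-yl in place of 3-methylbuta-1,3-dien-1-yl on a saturated chain carbon bound to an oxygen on a saturated carbon and two saturated chain carbons. The 1-methylbuta-1,3-dien-1-yl group replaces 3-methylbuta-1,3-dien-1-yl on a saturated chain carbon bound to an oxygen on a saturated carbon and two saturated chain carbons.

Going by the values given here, no measured compound carries the entering group, so no step measures this change directly. The nearest evidence comes from the three steps among the measured compounds, all of which alter the same unsaturated chain end. Two stay within the scatter, a 1.3-fold lower number from compound 1 to compound 2 (0.12 log units; within the scatter) and a 1.7-fold higher number from compound 1 to compound 3 (0.24 log units; within the scatter), and the largest is modest, a 2.3-fold higher number from compound 2 to compound 3 (0.36 log units; beyond the scatter). These steps suggest a small effect but give no direction for the new arrangement.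

The expected change is none beyond the scatter, a 1.2-fold lower number from compound 3 to compound 4 (0.08 log units; within the scatter). The range stays wide because the change itself is unmeasured. For compound 4 the estimated value is 0.35 mg/kg, with an expected range from 0.12 mg/kg to 1 mg/kg.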

Compound 4, dose for half-maximal effect: > 3.16 mg/kg
Compound 4 was reported as a limit (the forecaster's own chance of this, stated with the estimate: 3%); at least 9.0-fold (0.95 log units) between middle value and limit.
By their numbers in this assay, from the lowest: compounds 2, 1 and 3 (each within the scatter of the next, the first and the last beyond it). At a limit, above all of these: compound 4.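

Compound 4 is reported in this assay only as a limit, not as a number: the limit of > 3.16 mg/kg in this assay, at which 1 of the 4 values shown sits.

With 1-methylbuta-1,3-dien-1-yl in place of 3-methylbuta-1,3-dien-1-yl on the saturated chain carbon bound to the oxygen, the result is an at least 7.5-fold higher number from compound 3 to compound 4 (0.87 log units; beyond the scatter), and the comparisons with the other two compounds are an at least 17-fold higher number from compound 2 to compound 4 (1.23 log units; beyond the scatter) and an at least 13-fold higher number from compound 1 to compound 4 (1.11 log units; beyond the scatter). The earlier compounds shown here varied only the far end of the unsaturated chain, where the largest step was a 2.3-fold higher number from compound 2 to compound 3 (0.36 log units; beyond the scatter); this series now shows that shifting the methyl along the diene, with no change in atoms, counts for far more in this assay than any of those changes.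

From the compounds shown here alone, the limit leaves the upper size of all three new steps open, so it remains unknown how much compound 4 would need for the effect, or whether it would reach the effect at all. Also open, going by these compounds, is whether an ethyl in place of that methyl, or a saturated pentyl in place of the whole dienyl group, would give a number nearer compound 3 or compound 4.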